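A few compounds are considered here, and "the series" means these few. Any claim that something is new, unique, unknown or untested is made for them only; others in the source may bear on it.

Of the compounds shown here, three built on one shared core have been tested in a functional assay on A549 cells (Homo sapiens) for antiproliferative activity, read by MTT assay, with a stated time of 72 h; on this read-out lower numbers stand for stronger inhibition and higher numbers for weaker inhibition. Compound 1 `CCC/C=C/C(=O)Nc1cccc(Oc2nc(Nc3cccc(OC)c3)nc3c2CSCC3)c1` gives 11800 nM in this assay. Compound 2 `COc1cccc(Nc2nc3c(c(Oc4cccc(NC(=O)C=C(C)C)c4)n2)CSCC3)c1` differs from compound 1 by 2-methylprop-1-en-1-yl in place of pent-1-en-1-yl on a carbonyl carbon, and in this assay compound 2 gives 19800 nM, a step of a 1.7-fold higher number from compound 1 to compound 2 (0.22 log units; within the scatter). Compound 3 `CCC/C=C/C(=O)Nc1cccc(Oc2nc(Nc3ccc(OC)cc3)nc3c2CSCC3)c1` carries a different core, which differs from that of compound 1 by 4-methoxyphenyl in place of 3-methoxyphenyl on a nitrogen on an aromatic ring; in this assay compound 3 gives 11900 nM, a step of a 1.0-fold higher number from compound 1 to compound 3 (0.00 log units; within the scatter).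

Compound 4 `COc1ccc(Nc2nc3c(c(Oc4cccc(NC(=O)C=C(C)C)c4)n2)CSCC3)cc1` has not yet been measured in this assay. It differs from compound 3 by 2-methylprop-1-en-1-yl in place of pent-1-en-1-yl on a carbonyl carbon. This is the same change that was made from compound 1 to compound 2, made at the same place in the molecule, and it occurs twice among these compounds. Resting on the earlier step of a 1.7-fold higher number from compound 1 to compound 2 (0.22 log units; within the scatter), the expected step for compound 4 is a 1.7-fold higher number from compound 3 to compound 4 (0.23 log units; within the scatter). Compound 4 is therefore estimated at 20000 nM in this assay, with a likely range from 10000 nM to 40000 nM.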

Compound 4, half-maximal inhibitory concentration: 26900 nM
Compound 4: middle estimate off by 1.3-fold (0.13 log units), on the low side, and the stated range covers the measured number.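

The swap of pent-1-en-1-yl for 2-methylprop-1-en-1-yl on the carbonyl carbon gives a 2.3-fold higher number from compound 3 to compound 4 (0.35 log units; beyond the scatter), and in this assay this step agrees with the one seen on the core of compound 1, so the change carries over between these two cores: the same change on two cores in this assay, a 1.7-fold higher number (0.22 log units; within the scatter) from compound 1 to compound 2 and a 2.3-fold higher number (0.35 log units; beyond the scatter) from compound 3 to compound 4, 1.3-fold (0.13 log units) apart, within the scatter of two such steps. The other change, 4-methoxyphenyl in place of 3-methoxyphenyl on a nitrogen on an aromatic ring, gives a 1.4-fold higher number from compound 2 to compound 4 (0.13 log units; within the scatter), which stays within the scatter and also agrees with its earlier counterpart: the same change on two cores in this assay, a 1.0-fold higher number (0.00 log units; within the scatter) from compound 1 to compound 3 and a 1.4-fold higher number (0.13 log units; within the scatter) from compound 2 to compound 4, 1.3-fold (0.13 log units) apart, within the scatter of two such steps. Among these compounds, these are only two pairs among four compounds, and only the step to compound 4 from compound 3 lies beyond the scatter, so they show agreement here but no general rule for other cores, and they do not explain why the numbers behave this way.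

Still open, from the compounds shown here alone, is how the read-out responds to other groups on the same carbonyl carbon, such as a longer chain or a phenyl ring. The same question applies to replacing methoxy with a chlorine or an amine.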